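Compound 2 to compound 4: replacing the 3,4-dimethoxyphenyl group

This account rests on a few compounds, and the source may have more. Where it says the series, first, only, none or still open, it means among the compounds named here.

In a functional assay on KB cells (Homo sapiens) for inhibition, read by sulforhodamine B assay (a lower number here means a stronger inhibitor of growth, a higher number a weaker inhibitor of growth), compound 2 (`COc1ccc(-c2ccc(-c3ccc(-c4nc5cc(C)ccc5[nH]4)cc3)cc2)cc1OC`) gives 2190 nM and stands within the scatter of both other measured compounds. Compound 1 (`Cc1ccc2[nH]c(-c3ccc(-c4ccc(-c5cccc(Cl)c5)cc4)cc3)nc2c1`) gives 2260 nM on the same read-out, and compound 3 (`COc1ccc(-c2ccc(-c3ccc(-c4nc5c(O)cccc5[nH]4)cc3)cc2)cc1OC`) gives 2710 nM there.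

The next comparison is with compound 4 (`Cc1ccc2[nH]c(-c3ccc(-c4ccc(-c5ccc(F)cc5)cc4)cc3)nc2c1`), which carries 4-fluorophenyl in place of 3,4-dimethoxyphenyl on an aromatic carbon, para to a large group.

Within the data shown here, two measured steps bear on this change. At the same place, 3,4-dimethoxyphenyl in place of 3-chlorophenyl gave a 1.0-fold lower number from compound 1 to compound 2 (0.01 log units; within the scatter) and stayed within the scatter. A change to a different group, 4-hydroxy-1H-benzimidazol-2-yl in place of 5-methyl-1H-benzimidazol-2-yl, gave a 1.2-fold higher number from compound 2 to compound 3 (0.09 log units; within the scatter) and also stayed within the scatter. Neither step involves a 4-fluorophenyl group, and three values form a narrow base, so the range is kept wide.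

On this evidence, no shift beyond the scatter is expected in this assay. The expected step is a 1.1-fold lower number from compound 2 to compound 4 (0.04 log units; within the scatter) and it is small. Compound 4 is estimated at 2000 nM (expected range 800 nM to 4500 nM).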

Compound 4, concentration for 50% growth inhibition: 24900 nM
Beside the measured number, compound 4's estimate is 12-fold (1.10 log units) below it, and the stated range ends below it.
By their numbers in this assay, from the lowest: compounds 2, 1 and 3 (each within the scatter of the next); then compound 4.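

In this assay, the aromatic group at this position turns out not to be interchangeable: 4-fluorophenyl in place of 3,4-dimethoxyphenyl gives an 11-fold higher number from compound 2 to compound 4 (1.06 log units; beyond the scatter), and 4-fluorophenyl in place of 3-chlorophenyl gives an 11-fold higher number from compound 1 to compound 4 (1.04 log units; beyond the scatter). The earlier swap between the other two groups gave only a 1.0-fold lower number from compound 1 to compound 2 (0.01 log units; within the scatter), so the methoxy groups are not required for the lower numbers, since 3-chlorophenyl carries none, and the position's sensitivity appeared only with the 4-fluorophenyl group. The data offer no measured property or other evidence that would explain this large step.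

Still open, on these data alone, is whether the step follows from the fluorine itself or from where the substituent sits on the phenyl ring, a question that 3-fluorophenyl, 4-chlorophenyl and unsubstituted phenyl on the same core would help separate. Also open, as far as these compounds go, is whether 4-fluorophenyl has the same effect when paired with the 4-hydroxy-1H-benzimidazol-2-yl group of compound 3.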